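Following one group swap from compound 2 to compound 3

A few compounds are considered here, and "the series" means these few. Any claim that something is new, unique, unknown or untested is made for them only; others in the source may bear on it.

Compound 1 (`COC(=O)CC[C@@H]1NC(=O)[C@@H](C)NC(=O)[C@@H]2Cc3ccc(OC)c(c3)Oc3ccc(cc3)C[C@@H](C(=O)N2C)N(C)C(=O)[C@H](C)NC(=O)[C@H](Cc2ccc(OC)cc2)N(C)C1=O`) gives (58.9 nM)
Compound 2 (`COc1ccc2cc1Oc1ccc(cc1)C[C@H]1C(=O)N(C)[C@@H](C2)C(=O)N[C@H](C)C(=O)N[C@@H](C)C(=O)N(C)[C@@H](Cc2ccc(C)cc2)C(=O)N[C@@H](C)C(=O)N1C`) gives (24 nM)

Both numbers come from a functional assay on P388 cells (Mus musculus) for cytotoxicity; on this read-out lower numbers stand for stronger inhibition and higher numbers for weaker inhibition. Compound 2 has the lower number of the two, and its gap to compound 1 lies beyond the usual scatter of repeated measurements. Among the measured compounds shown here, no measured pair differs in one place only, so no measured step can serve as a direct guide.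

The next molecule is compound 3 (`COc1ccc(C[C@H]2C(=O)N[C@@H](C)C(=O)N(C)[C@H]3Cc4ccc(cc4)Oc4cc(ccc4OC)C[C@@H](C(=O)N[C@H](C)C(=O)N[C@@H](C)C(=O)N2C)N(C)C3=O)cc1O`), which keeps the shared core of compound 2 and changes one group (3-hydroxy-4-methoxyphenyl in place of 4-methylphenyl on a saturated chain carbon bound to a saturated ring carbon). Here 3-hydroxy-4-methoxyphenyl stands in place of 4-methylphenyl on a saturated chain carbon bound to a saturated ring carbon.

With so little data, only a small upward step is expected in this assay, probably within the scatter. For the measured compounds named here, compound 2 holds the lowest number so far, and compound 1 (58.9 nM) shows that a number can sit higher. In numbers, the expected change is a 1.7-fold higher number from compound 2 to compound 3 (0.22 log units; within the scatter). For compound 3 the estimated value is 40 nM, with an expected range from 13 nM to 120 nM.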

Compound 3, half-maximal inhibitory concentration: 214 nM
The estimate for compound 3 lay 5.4-fold (0.73 log units) below the measured number, outside the stated range (above it).
By their numbers in this assay, from the lowest: compound 2; then compound 1; then compound 3.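

Replacing 4-methylphenyl with 3-hydroxy-4-methoxyphenyl on a saturated chain carbon bound to a saturated ring carbon gives an 8.9-fold higher number from compound 2 to compound 3 (0.95 log units; beyond the scatter) in this assay, so the number in this series is sensitive to the group at this place. Compound 1 and compound 2 differ in more than one place and could not show this; here, a single group change on an otherwise shared core is tied directly to a rise beyond the scatter. The entering group brings two oxygen atoms, one hydrogen-bond donor and two hydrogen-bond acceptors that the leaving group lacks, but no available measurement explains why the number rose.

The compounds shown leave open whether the hydroxy group, the methoxy group or only the two together go with this weaker inhibition, and a phenyl ring carrying just one of them would separate these cases. They also leave open how this place responds to other groups on the phenyl ring, such as an amine, a carboxylic acid or a longer alkyl chain in place of the methyl group.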